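Swapping Fluorines for Chlorines on the Sulfonyl Aryl Ring

This account rests on a few compounds, and the source may have more. Where it says the series, first, only, none or still open, it means among the compounds named here.

Compound 1 `CC1CCN(c2c(S(=O)(=O)c3cccc(F)c3)cnc3ccc(Cl)cc23)CC1`: 58%
Compound 2 `CC1CCN(c2c(S(=O)(=O)c3cccc(C#N)c3)cnc3ccc(Cl)cc23)CC1`: 90%
Compound 3 `CC1CCN(c2c(S(=O)(=O)c3cc(F)cc(F)c3)cnc3ccc(Cl)cc23)CC1`: 93%

In an assay on isolated protein for displacement of a labelled ligand from metabotropic glutamate receptor 5 (Homo sapiens), with a stated time of 60 min, tested at 1 uM (a lower number here means less inhibition, a higher number more inhibition at the concentration tested (going by the name of the read-out)), compound 3 gives the highest of the three numbers, though its gap to compound 2 is within the scatter, while compound 1 lies well below it. Compound 4 `CC1CCN(c2c(S(=O)(=O)c3cc(Cl)cc(Cl)c3)cnc3ccc(Cl)cc23)CC1` differs from compound 3 only at the sulfonyl sulfur: 3,5-dichlorophenyl in place of 3,5-difluorophenyl on a sulfonyl sulfur. Going by the values given here, no measured step exchanges fluoro for chloro. The steps that touch this ring, a number 35 percentage points higher from compound 1 to compound 3 (beyond the scatter) and a number 3 percentage points higher from compound 2 to compound 3 (within the scatter), show that a second substituent lifts the read-out strongly, whereas swapping one substituted ring for another changes little. Compound 4 is therefore expected to stay near the top, with a step of a number 5 percentage points lower from compound 3 to compound 4 (within the scatter), so compound 4 is estimated at 88% within 70% to 98%.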

Compound 4, a percentage reported as inhibition, at one concentration (the size of the read-out at that concentration, not a potency): 88%
Compound 4: middle estimate and measured number agree at the digits printed, within the range that was stated.
By their numbers in this assay, from the lowest: compound 1; then compounds 4, 2 and 3 (each within the scatter of the next).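

In this assay, chlorine in place of fluorine on this ring gives a number 5 percentage points lower from compound 3 to compound 4 (within the scatter), so the position on the sulfonyl sulfur takes 3,5-dichlorophenyl as readily as 3,5-difluorophenyl. Against the 3-cyanophenyl compound there is a number 2 percentage points lower from compound 2 to compound 4 (within the scatter), whereas the 3-fluorophenyl compound stands apart, with a number 30 percentage points higher from compound 1 to compound 4 (beyond the scatter). No measurement at hand explains these readings.

The compounds shown leave open whether 3-chlorophenyl on the sulfonyl sulfur would read like compound 1 or like compound 4. They also leave open how a ring carrying an amine or a methoxy group would read.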